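A Methyl Added to the Hydroxyphenyl Ring of Compound 1

The source may report more compounds than this note shows. Statements on the series, on what has been measured and on what is new or still open speak of the compounds shown alone.

Compound 1 `Cc1c(C(=O)N/N=C\c2ccccc2O)oc2cccc(O)c12` was tested in a functional assay on PC-3 cells (Homo sapiens) for inhibition (a higher number here means a weaker inhibitor, a lower number a stronger inhibitor), where compound 1 gives 8350 nM. Compound 3 `Cc1c(C(=O)N/N=C\c2cccc(F)c2O)oc2cccc(O)c12`, which carries fluoro in place of hydrogen on an aromatic carbon, gives 12700 nM in this assay. Compound 2 `Cc1c(C(=O)N/N=C\c2cccc(F)c2)oc2cccc(O)c12` reaches only a limit in this assay, >= 40000 nM. Of the two numbers available, compound 1 has the lowest, and compound 3 sits within the scatter of it.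

Compound 4 `Cc1ccc(O)c(/C=N\NC(=O)c2oc3cccc(O)c3c2C)c1` differs from compound 1 by methyl in place of hydrogen on an aromatic carbon. Going by the values given here, no measured step alters this position. The nearest guide is compound 3, where a small group enters the same ring and the step of a 1.5-fold higher number from compound 1 to compound 3 (0.18 log units; within the scatter) stays within the scatter. The steps of an at least 4.7-fold higher number from compound 1 to compound 2 (0.68 log units; beyond the scatter) and an at least 3.1-fold lower number from compound 2 to compound 3 (0.49 log units; beyond the scatter) concern the hydroxy group, which compound 4 keeps, and only set the limit of >= 40000 nM in this assay, at which 1 of the 3 values shown sits, apart from the rest. A step within the scatter is therefore expected in this assay: a 1.1-fold lower number from compound 1 to compound 4 (0.05 log units; within the scatter). Compound 4 is accordingly estimated at 7500 nM, in the range 3000 nM to 20000 nM.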

Compound 4, half-maximal inhibitory concentration: 7350 nM
Compound 4: middle estimate off by 1.0-fold (0.01 log units), on the high side, and the stated range covers the measured number.
By their numbers in this assay, from the lowest: compounds 4, 1 and 3 (each within the scatter of the next). At a limit, above all of these: compound 2.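

In this assay, methyl on this aromatic carbon, para to a hydroxy group, gives a step that cannot be told from repeat measurements, a 1.1-fold lower number from compound 1 to compound 4 (0.06 log units; within the scatter), and the exchange of the 3-fluoro-2-hydroxyphenyl group for 2-hydroxy-5-methylphenyl also stays small, a 1.7-fold lower number from compound 3 to compound 4 (0.24 log units; within the scatter). Going by these compounds alone, the only step here beyond the scatter is the one that restores the hydroxy group while also changing the fluoro and methyl substituents, an at least 5.4-fold lower number from compound 2 to compound 4 (0.73 log units; beyond the scatter), so the methyl group does not disturb the separation seen with the hydroxy-bearing compounds. Compound 2 remains a limit and not a number: the limit of >= 40000 nM in this assay, at which 1 of the 4 values shown sits.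

What the compounds shown leave open is whether a longer chain such as ethyl, an amine or a carboxylic acid at this same carbon would also stay within the scatter of compound 1. They also do not show whether methyl on another carbon of this ring would behave the same way in this assay.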